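Swapping fluoro for methyl on two related cores

The compounds below may be only part of what the source reports. "The series", "measured", "known", "first", "only" and "open" are said of these compounds alone.

Compound 1, `COc1cc(C(=O)c2sc(Nc3ccc(F)cc3)nc2N)cc(OC)c1OC`: 400 nM
Compound 2, `COc1cc(C(=O)c2sc(Nc3ccc(C)cc3)nc2N)cc(OC)c1OC`: 41 nM
Compound 3, `Nc1nc(Nc2ccc(F)cc2)sc1C(=O)c1ccccc1`: > 10000 nM

Of the compounds shown here, three have been tested in a functional assay on CCRF-CEM cells (Homo sapiens) for antiproliferative activity, read by cell counting, with a stated time of 2 days; on this read-out lower numbers stand for stronger inhibition and higher numbers for weaker inhibition. Compound 1, `COc1cc(C(=O)c2sc(Nc3ccc(F)cc3)nc2N)cc(OC)c1OC`, gives 400 nM in this assay. Compound 2, `COc1cc(C(=O)c2sc(Nc3ccc(C)cc3)nc2N)cc(OC)c1OC`, gives 41 nM. The change between them is methyl in place of fluoro on an aromatic carbon, and it brings a 9.8-fold lower number from compound 1 to compound 2 (0.99 log units; beyond the scatter).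

Compound 3, `Nc1nc(Nc2ccc(F)cc2)sc1C(=O)c1ccccc1`, is built on a different core, and the difference between the two cores is not broken down here. For compound 3 this assay reports only a limit, (the limit of > 10000 nM in this assay, at which 1 of the 3 values shown sits), so its value is not a number.

Compound 4, `Cc1ccc(Nc2nc(N)c(C(=O)c3ccccc3)s2)cc1`, has not yet been measured. It differs from compound 3 by methyl in place of fluoro on an aromatic carbon. This is the same change that turns compound 1 into compound 2, made at the same kind of place on the ring. Because compound 1 to compound 2 gives a 9.8-fold lower number from compound 1 to compound 2 (0.99 log units; beyond the scatter), a step of similar size is expected for compound 4, so an estimated step of an at least 2.0-fold lower number from compound 3 to compound 4 (0.30 log units; that floor lies within the scatter). Since the value for compound 3 is only a limit, the starting point is uncertain, and compound 4 may itself come back as a limit. For compound 4 the expected value in this assay is 5000 nM, estimated to lie between 1000 nM and 20000 nM.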

Compound 4, half-maximal inhibitory concentration: 370 nM
The estimate for compound 4 lay 14-fold (1.13 log units) above the measured number; the whole stated range lies above it.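

Putting methyl in place of fluoro lowers the number again in this assay, with an at least 27-fold lower number from compound 3 to compound 4 (1.43 log units; beyond the scatter), so the direction of the change carries over from the core of compound 1 to the core of compound 3. The size of the step does not carry over, and a step measured on one core would not have given a safe figure for the other: the same change on two cores in this assay, a 9.8-fold lower number (0.99 log units; beyond the scatter) from compound 1 to compound 2 and an at least 27-fold lower number (1.43 log units; beyond the scatter) from compound 3 to compound 4, at least 2.7-fold (0.44 log units) apart, beyond the scatter of two such steps What this does not show is the true size of the larger step, or any rule for cores beyond these two, for compound 3 is reported only as a limit and not as a number: the limit of > 10000 nM in this assay, at which 1 of the 4 values shown sits.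

The compounds shown carry only fluoro or methyl in the place para to a large group, so it stays open whether a chlorine atom, a methoxy group or a longer chain such as ethyl would behave like methyl in this assay. Also open, from the compounds shown here alone, is whether an amine or a carboxylic acid in that place would keep the number low, and whether the swap from 4-fluorophenyl to 4-methylphenyl would point the same way on a third core.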